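A few compounds are considered here, and "the series" means these few. Any claim that something is new, unique, unknown or untested is made for them only; others in the source may bear on it.

Working notes on the series.

Compound 1, `Fc1cc(Cl)ccc1-c1ccc(Cn2nnc3ccccc32)cn1`, gives 50 nM in a functional assay on cells for positive allosteric modulation of metabotropic glutamate receptor 2 (Homo sapiens), read by fluorescence and calcium flux, with a stated time of 30 min; a lower number here means that less compound is needed, a higher number that more compound is needed for the effect. Compound 2, `Fc1cc(Cl)ccc1-c1ccc(Cn2nnc3c(C(F)(F)F)cccc32)cn1`, carries the change trifluoromethyl in place of hydrogen on an aromatic carbon relative to compound 1. In this assay compound 2 gives 13 nM. That change produced a 3.8-fold lower number from compound 1 to compound 2 (0.59 log units; beyond the scatter).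

Compound 3, `Brc1cccc2c1nnn2CC1CC1`, rests on a different core; the difference between the two cores is not broken down here. In this assay compound 3 gives 70 nM, a number within the scatter of that of compound 1 and beyond the scatter of that of compound 2.

Compound 4, `FC(F)(F)c1cc(Br)c2nnn(CC3CC3)c2c1`, is not yet measured. It is made from compound 3 by the change (trifluoromethyl in place of hydrogen on an aromatic carbon). This is the same kind of change as that from compound 1 to compound 2, but the surroundings of the place are not the same: in compound 2 the entering group stands ortho to a fused ring and meta to a fused ring, whereas in compound 4 it stands meta to a bromo group, meta to a fused ring and para to a fused ring.

For the measured compounds named here, the expectation for compound 4 in this assay is a step of a 2.5-fold lower number from compound 3 to compound 4 (0.40 log units; beyond the scatter), set beside the earlier one; it rests on the single measured instance of this kind of change, a 3.8-fold lower number from compound 1 to compound 2 (0.59 log units; beyond the scatter), tempered because the place differs and because compound 3, at 70 nM, sits on another core. Compound 4 is thus estimated at 28 nM, with a plausible range from 12 nM to 70 nM.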

Compound 4, half-maximal effective concentration: 140 nM
For compound 4 the middle estimate is 5.0-fold (0.70 log units) below the measured one; measured number outside the range, above it.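

In this assay, trifluoromethyl in place of hydrogen on an aromatic carbon gives a 2.0-fold higher number from compound 3 to compound 4 (0.30 log units; within the scatter), so the lower number seen on the core of compound 1 does not reappear on the core of compound 3, and the two steps differ: the same change on two cores in this assay, a 3.8-fold lower number (0.59 log units; beyond the scatter) from compound 1 to compound 2 and a 2.0-fold higher number (0.30 log units; within the scatter) from compound 3 to compound 4, 7.7-fold (0.89 log units) apart, beyond the scatter of two such steps. For these two pairs, then, the size and direction of the step on one core give no safe guide to the step on the other, and compound 3 and compound 4 cannot be told apart in this read-out. This does not show which difference matters, as the two pairs differ together in their core and in the place of the change, which in compound 4 is meta to a bromo group, meta to a fused ring and para to a fused ring; two pairs also give no general rule for the series.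

As far as these compounds go, it remains open whether trifluoromethyl would behave differently at another place on the core of compound 3, and whether the outcome at the present place depends on the bromo group. A nitrile or a methyl group at that same place would show whether the result is particular to trifluoromethyl.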